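A few compounds are considered here, and "the series" means these few. Any claim that something is new, unique, unknown or untested is made for them only; others in the source may bear on it.

Working notes on the series.

All compounds share one core, carrying an azepane-containing chain on the aromatic nitrogen; they differ in the length of that chain. Compound 1 `CCC(=O)c1ccc2c(c1)sc(=O)n2CCN1CCCCCC1` is the shortest member. In an assay on cell membranes for displacement of a labelled ligand from Sigma non-opioid intracellular receptor 1 (Rattus norvegicus) (a lower number here means a stronger inhibitor, a higher number a weaker inhibitor), compound 1 gives 4.5 nM. Compound 2 `CCC(=O)c1ccc2c(c1)sc(=O)n2CCCN1CCCCCC1` carries one more chain carbon; the change is (azepan-1-yl)methyl in place of azepan-1-yl on a saturated chain carbon, two bonds along the chain from an aromatic nitrogen. In this assay compound 2 gives 3.7 nM, and the step is a 1.2-fold lower number from compound 1 to compound 2 (0.09 log units; within the scatter), so the two read as equivalent. Compound 3 `CCC(=O)c1ccc2c(c1)sc(=O)n2CCCCCN1CCCCCC1` is longer again; how its core relates to that of compound 1 is not broken down here. In this assay compound 3 gives 12.2 nM, the highest number of the three and beyond the scatter against both compound 1 and compound 2.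

Compound 4 `CCC(=O)c1ccc2c(c1)sc(=O)n2CCCCCCN1CCCCCC1` is not yet measured. It differs from compound 3 by (azepan-1-yl)methyl in place of azepan-1-yl on a saturated chain carbon, five bonds along the chain from an aromatic nitrogen. This is the same kind of change as that from compound 1 to compound 2, but it sits five bonds along the chain from the aromatic nitrogen rather than two bonds, so the earlier step is only a rough guide. The one measured chain extension was flat; the longer extension from compound 2 to compound 3 gave a higher number. For compound 4 the expected step is a 1.3-fold higher number from compound 3 to compound 4 (0.12 log units; within the scatter), a small rise or no change, resting on the flat step from compound 1 to compound 2 and the higher value of compound 3. The estimate for compound 4 in this assay is 16 nM, expected between 6 nM and 45 nM.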

Compound 4, inhibition constant: 10.4 nM
Compound 4: middle estimate off by 1.5-fold (0.19 log units), on the high side; the range from low to high includes it.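

Replacing azepan-1-yl with (azepan-1-yl)methyl five bonds along the chain from an aromatic nitrogen gives a 1.2-fold lower number from compound 3 to compound 4 (0.07 log units; within the scatter) in this assay, and this step does not differ from the one seen with the same change two bonds along the chain: the same change on two cores in this assay, a 1.2-fold lower number (0.09 log units; within the scatter) from compound 1 to compound 2 and a 1.2-fold lower number (0.07 log units; within the scatter) from compound 3 to compound 4, 1.0-fold (0.02 log units) apart, within the scatter of two such steps Within this series, then, the change carries from the core of compound 1 to the core of compound 3 as a step within the scatter on both, so the earlier step was a fair guide to the later one. Within the data shown here, this rests on only two pairs in one assay, both of them flat, so it does not show how a step beyond the scatter would carry over, and it does not account for the longer extension separating compound 2 at 3.7 nM from compound 3 at 12.2 nM.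

The compounds shown leave open whether the extension stays flat with a piperidine or a morpholine in place of the azepane. They also leave open what a chain longer than that of compound 4 would give, and whether the pattern holds with an acetyl or butanoyl group in place of the propanoyl group on the shared core.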